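Replacing the Hydroxy Group of Compound 3

The source may hold more compounds than are shown below. What is called first, only, known or untested is meant among the compounds shown, and "the series" means these compounds.

In a functional assay on the whole organism for inhibition, with Cavia porcellus as the target (a lower number here means that less compound is needed, a higher number that more compound is needed for the effect), compound 3 `COc1ccccc1OCC1SCCN1C(=O)CC(=O)O` gives 20 mg/kg. Compound 1 `COc1ccccc1OCC1SCCN1C(=O)CNC(C)=O` gives 40 mg/kg, which is within the scatter of compound 3, and compound 2 `CCCC(=O)CC(=O)N1CCSC1COc1ccccc1OC` gives 42 mg/kg. Compound 4 `CCN(CC)CCNC(=O)CC(=O)N1CCSC1COc1ccccc1OC` is still unmeasured. It has (2-(diethylamino)ethyl)amino in place of hydroxy on a carbonyl carbon. The closest measured change at this carbonyl carbon is modest, a 2.1-fold lower number from compound 2 to compound 3 (0.32 log units; beyond the scatter). Changing the end group more broadly also gave only a 2.0-fold lower number from compound 1 to compound 3 (0.30 log units; within the scatter). Among the compounds with values here, no measured compound carries the entering group, so this evidence is indirect. A small rise is expected, a 1.5-fold higher number from compound 3 to compound 4 (0.18 log units; within the scatter), which stays within the scatter. For compound 4 the estimate is 30 mg/kg, with an expected range of 12 mg/kg to 75 mg/kg.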

Compound 4, dose for half-maximal effect: 56 mg/kg
Estimate against measurement, compound 4: 1.9-fold (0.27 log units) below, and the stated range covers the measured number.
By their numbers in this assay, from the lowest: compounds 3, 1, 2 and 4 (each within the scatter of the next, the first and the last beyond it).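

On this carbonyl carbon in this assay, (2-(diethylamino)ethyl)amino in place of hydroxy gives a 2.8-fold higher number from compound 3 to compound 4 (0.45 log units; beyond the scatter), so a much larger end group is accommodated at a modest cost. In place of propyl, the same group gives a 1.3-fold higher number from compound 2 to compound 4 (0.12 log units; within the scatter), so this position does not separate these two end groups. Nothing measured here explains either step.

The compounds shown leave open whether the rise follows the whole chain or its diethylamino end. On these data alone, a simple ethylamino group or a methyl ester on this carbonyl carbon remains untested among them.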